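Taking the bromo group off compound 2

This account rests on a few compounds, and the source may have more. Where it says the series, first, only, none or still open, it means among the compounds named here.

In a functional assay on NCI-H522 cells (Homo sapiens) for cytotoxicity, with a stated time of 3 days (a lower number here means a stronger inhibitor, a higher number a weaker inhibitor), compound 1 `C#Cc1nc2ccccc2[se]1` gives 2170 nM, and compound 3 `Cn1c(I)nc2ccccc21` gives 1020 nM. Compound 2 `Brc1nc2ccccc2[se]1` reads > 40000 nM, which is a limit of the assay and not a number. That places compound 2 at the limit of > 40000 nM in this assay, at which 1 of the 3 values shown sits.

The next structure, compound 4 `c1ccc2[se]cnc2c1`, has hydrogen in place of bromo on an aromatic carbon. Within the data shown here, no measured step makes this exact swap. The nearest one, bromo in place of ethynyl on the same carbon, gave an at least 18-fold higher number from compound 1 to compound 2 (1.26 log units; beyond the scatter), a large step beyond the scatter. Compound 4 lacks the ethynyl of compound 1, as compound 2 does, so that large step an at least 18-fold higher number from compound 1 to compound 2 (1.26 log units; beyond the scatter) gives no reason to expect a return to the values of compound 1.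

Only a small step in this assay is therefore expected, towards a lower number if there is any change at all, and it is estimated as an at least 1.3-fold lower number from compound 2 to compound 4 (0.12 log units; that floor lies within the scatter). For compound 4, the estimated value is 30000 nM, with an expected range from 8000 nM to 50000 nM.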

Compound 4, half-maximal inhibitory concentration: > 40000 nM
Compound 4 gave a limit, no number; the forecaster's own chance of this, stated with the estimate: 55%; at least 1.3-fold (0.12 log units) between middle value and limit.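

In this assay replacing the ethynyl of compound 1 with hydrogen gives an at least 18-fold higher number from compound 1 to compound 4 (1.26 log units; beyond the scatter) and so matches what bromo did at this carbon, next to the ring nitrogen and next to the ring selenium. The ethynyl therefore stands apart here not only from a halogen but also from the bare core, which carries no group at this place. Compound 4 reads as a limit, as compound 2 does, so the step between them cannot be read and neither group can be ranked above the other, the two sharing one limit: the limit of > 40000 nM in this assay, at which 2 of the 4 values shown sit.

Still open, from the compounds shown here alone, is whether the ethynyl itself is needed, or whether another group on this carbon, such as a nitrile, an amine or a longer alkyne chain, would bring the number back towards that of compound 1.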